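The compounds below may be only part of what the source reports. "The series", "measured", "known", "first", "only" and "open" are said of these compounds alone.

Going by the values given here, compound 1 `C=C1[C@@H](OC(C)=O)C[C@@H]2[C@](C)(CO[Si](C)(C)C(C)(C)C)[C@H](OC(C)=O)CC[C@@]2(C)[C@@H]1C[C@@H](Nc1ccc(Br)cc1)C1=CCOC1=O` carries the only number in the set: in a functional assay on MCF7 cells (Homo sapiens) for cytotoxicity, read by sulforhodamine B assay (on this read-out lower numbers stand for stronger inhibition and higher numbers for weaker inhibition), compound 1 gives 3920 nM. Compound 2 `C=C1[C@@H](OC(C)=O)C[C@@H]2[C@](C)(COC=O)[C@H](OC(C)=O)CC[C@@]2(C)[C@@H]1C[C@@H](Nc1ccc(OC)c(OC)c1)C1=CCOC1=O` stands apart, since in this assay compound 2 gives > 50000 nM, a limit of the assay rather than a number (the limit of > 50000 nM in this assay, at which 1 of the 2 values shown sits). Compound 3 `C=C1[C@@H](OC(C)=O)C[C@@H]2[C@](C)(CO[Si](C)(C)C(C)(C)C)[C@H](OC(C)=O)CC[C@@]2(C)[C@@H]1C[C@@H](Nc1ccc(OC)cc1)C1=CCOC1=O` is not yet measured. It differs from compound 1 in one place: methoxy in place of bromo on an aromatic carbon. No step between two measured compounds is available, so nothing shown sizes this change. For compound 3 the step is estimated to stay within the scatter, a 1.4-fold higher number from compound 1 to compound 3 (0.15 log units; within the scatter). Compound 3 is expected near 5500 nM, in the range 1500 nM to 25000 nM.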

Compound 3, half-maximal inhibitory concentration: 4280 nM
The estimate for compound 3 lay 1.3-fold (0.11 log units) above the measured number; measured number inside the range.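

Methoxy in place of bromo on an aromatic carbon, para to a large group, gives a 1.1-fold higher number from compound 1 to compound 3 (0.04 log units; within the scatter) in this assay, the only readable sizing of a change at this position. Within this pair, the position takes either bromo or methoxy with no separation in this assay. No measured property shown bears on this step.

As far as these compounds go, whether a carboxylic acid, a dimethylamino group or a longer alkoxy chain on this carbon would keep the number within the scatter remains open. Also open, from the compounds shown here alone, is how far a single change elsewhere on the shared core would move it.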